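Amide to urea at the chain end of compound 3

A few compounds are considered here, and "the series" means these few. Any claim that something is new, unique, unknown or untested is made for them only; others in the source may bear on it.

Compound 3 `CNC(=O)CCCCCCn1c(C)nc(-c2ccccc2)c1-c1ccccc1` stands second highest of the three numbers in an assay on H4 cells for inhibition of Fatty-acid amide hydrolase 1 (Homo sapiens) (a lower number here means a stronger inhibitor, a higher number a weaker inhibitor), where compound 3 gives 1700 nM. Compound 1 `CCOC(=O)CC(C)CCCCCn1c(C)nc(-c2ccccc2)c1-c1ccccc1` gives 130 nM in this assay, and compound 2 `CCOC(=O)CC(CC)CCCCCn1c(C)nc(-c2ccccc2)c1-c1ccccc1` gives 9900 nM. The change now followed is to compound 4 `CNC(=O)NCCCCCCn1c(C)nc(-c2ccccc2)c1-c1ccccc1`, which differs from compound 3 only in this: (methylcarbamoyl)amino in place of methylcarbamoyl on a saturated chain carbon, six bonds along the chain from an aromatic nitrogen.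

Within the data shown here, none of the measured steps alters this part of the chain in this way. The step of a 13-fold higher number from compound 1 to compound 3 (1.12 log units; beyond the scatter) and the step of a 5.8-fold lower number from compound 2 to compound 3 (0.77 log units; beyond the scatter) exchange the whole ester-bearing tail for the methylcarbamoyl end, and the step of a 76-fold higher number from compound 1 to compound 2 (1.88 log units; beyond the scatter) adds a methyl on the chain; all three are beyond the scatter, which shows that the tail of the shared core is sensitive to change, but none of them separates an amide end from a urea end. Only the added nitrogen, with its second hydrogen-bond donor, is new here. In this assay the expected step is therefore a 1.1-fold lower number from compound 3 to compound 4 (0.05 log units; within the scatter), in no firmly founded direction, and the range is set wide to cover a step of the size seen in the tail changes.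

Compound 4 is estimated at 1500 nM in this assay, within 300 nM to 8000 nM.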

Compound 4, half-maximal inhibitory concentration: > 10000 nM
Compound 4 was reported as a limit; the forecaster's own chance of this, stated with the estimate: 5%; at least 6.6-fold (0.82 log units) between middle value and limit.
By their numbers in this assay, from the lowest: compound 1; then compound 3; then compound 2. At a limit, above all of these: compound 4.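

In this assay compound 4 gives > 10000 nM, which is a limit and not a number. Even so, the chain end now proves sensitive to a change that the earlier compounds did not test: (methylcarbamoyl)amino in place of methylcarbamoyl, on a saturated chain carbon six bonds along the chain from an aromatic nitrogen, gives an at least 5.8-fold higher number from compound 3 to compound 4 (0.76 log units; beyond the scatter), so the amide and urea ends are not interchangeable here. Against the ester-bearing tail of compound 1 the change in tail gives an at least 76-fold higher number from compound 1 to compound 4 (1.88 log units; beyond the scatter), whereas the other such step is a number no lower from compound 2 to compound 4 (the limit leaves the size open).

On these data alone, how far compound 4 lies past its limit remains open, and with it the full size of the loss from the amide end to the urea end. Also open, as far as these compounds go, is whether the inserted nitrogen itself is decisive, which a carbamate end, with oxygen in that place, or a urea on a longer chain would help to separate from the effect of the added length.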